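A few compounds are considered here, and "the series" means these few. Any claim that something is new, unique, unknown or untested is made for them only; others in the source may bear on it.

In a functional assay on B16 cells (Mus musculus) for cytotoxicity, read by MTT assay, with a stated time of 3 days (a higher number here means a weaker inhibitor, a lower number a stronger inhibitor), compound 1 `COc1cc(/C=C/C(=O)c2ccc(OC)c([N+](=O)[O-])c2)cc(OC)c1` gives 5600 nM. Compound 2 `COc1ccc(/C=C/C(=O)c2ccc(OC)c([N+](=O)[O-])c2)cc1OC` sits at the limit of this assay, where its reading is > 100000 nM and not a number; one of the two values shown sits there (the limit of > 100000 nM in this assay, at which 1 of the 2 values shown sits). Compound 3 `COc1ccc(C(=O)/C=C/c2cc(OC)c(OC)c(OC)c2)cc1[N+](=O)[O-]` carries methoxy in place of hydrogen on an aromatic carbon. Going by the values given here, no measured step bears on this change, so the expectation rests on compound 1, whose reading of 5600 nM shows that a related arrangement of methoxy groups gives a measurable value. Compound 3 is therefore expected to move well inside the range of this assay, a step of an at least 40-fold lower number from compound 2 to compound 3 (1.60 log units; beyond the scatter), to an estimated 2500 nM within 300 nM to 30000 nM.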

Compound 3, half-maximal inhibitory concentration: > 100000 nM
Compound 3 gave a limit, no number; the forecaster's own chance of this, stated with the estimate: 15%; at least 40-fold (1.60 log units) between middle value and limit.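

Methoxy in place of hydrogen on an aromatic carbon weakens the reading in this assay: the change gives an at least 17-fold higher number from compound 1 to compound 3 (1.25 log units; beyond the scatter). Compound 3 reads > 100000 nM, which is a limit and not a number. The step from compound 2 to compound 3 cannot be read, as both ends of it are limits: the limit of > 100000 nM in this assay, at which 2 of the 3 values shown sit.

As far as these compounds go, whether this loss belongs to methoxy itself or to any group at this place stays open, as does how a hydroxyl or an amine there would read. From the compounds shown here alone, how far past the limit compound 2 and compound 3 lie also remains unknown.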